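Diaryl urea series: halogen pattern on the terminal ring

The source may report more compounds than this note shows. Statements on the series, on what has been measured and on what is new or still open speak of the compounds shown alone.

Measured so far:
compound 1 `CN(C)CCn1cnnc1-c1cc(Oc2ccc(NC(=O)Nc3ccc(F)c(F)c3)cc2F)ccn1` gives 9050 nM
compound 2 `CN(C)CCn1cnnc1-c1cc(Oc2ccc(NC(=O)Nc3ccc(F)c(Cl)c3)cc2F)ccn1` gives 1580 nM

In a functional assay on NCI-H460 cells (Homo sapiens) for antiproliferative activity, read by MTT assay, with a stated time of 72 h (a lower number here means a stronger inhibitor, a higher number a weaker inhibitor), compound 2 holds the lower of the two numbers, set apart from compound 1 by a 5.7-fold lower number from compound 1 to compound 2 (0.76 log units; beyond the scatter). Compound 3 `CN(C)CCn1cnnc1-c1cc(Oc2ccc(NC(=O)Nc3ccc(Cl)cc3Cl)cc2F)ccn1` differs from compound 2 by 2,4-dichlorophenyl in place of 3-chloro-4-fluorophenyl on an amide-type nitrogen. For the measured compounds named here, the single measured step concerned chloro in place of fluoro on this same ring and bears only indirectly on a rearranged halogen pattern, so it offers no firm direction. A modest weakening is expected, a 2.0-fold higher number from compound 2 to compound 3 (0.31 log units; beyond the scatter), with wide uncertainty. Compound 3 is estimated at 3200 nM, range 800 nM to 13000 nM.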

Compound 3, half-maximal inhibitory concentration: 4350 nM
Estimate against measurement, compound 3: 1.4-fold (0.13 log units) below; the range from low to high includes it.
By their numbers in this assay, from the lowest: compound 2; then compound 3; then compound 1.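

In this assay, exchanging the terminal ring gives a 2.8-fold higher number from compound 2 to compound 3 (0.44 log units; beyond the scatter), so 2,4-dichlorophenyl on the amide-type nitrogen falls short of 3-chloro-4-fluorophenyl despite carrying two chlorines. Against 3,4-difluorophenyl, the same ring still gives a 2.1-fold lower number from compound 1 to compound 3 (0.32 log units; beyond the scatter), so the halogen arrangement matters here as well as the presence of chlorine. No supporting evidence accounts for this order. The shown compounds leave open how the step divides between the moved chlorine and the lost fluorine. They also leave open where a terminal ring bearing trifluoromethyl or methoxy would fall.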